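The source may hold more compounds than are shown below. What is called first, only, known or untested is meant among the compounds shown, and "the series" means these compounds.

Values in a functional assay on BaF3 cells (Mus musculus) for inhibition, read by CCK-8 assay, with a stated time of 72 h; on this read-out lower numbers stand for stronger inhibition of growth and higher numbers for weaker inhibition of growth:
- compound 1 `CC(=O)Nc1cc(Oc2ccc(NC(=O)Nc3ccc(CN4CCN(C)CC4)c(C(F)(F)F)c3)cc2)ncn1`: 50 nM
- compound 2 `COc1ccc(CNc2cc(Oc3ccc(NC(=O)Nc4ccc(C)c(C(F)(F)F)c4)cc3)ncn2)cc1`: 1000 nM
- compound 3 `Cc1ccc(NC(=O)Nc2ccc(Oc3cc(NCc4ccccc4)ncn3)cc2)cc1C(F)(F)F`: 3010 nM

Compound 3 has the highest number of the three, so it is the weakest growth inhibitor here. The next analogue, compound 4 `Cc1ccc(NC(=O)Nc2ccc(Oc3cc(N4CCNC[C@H]4C)ncn3)cc2)cc1C(F)(F)F`, carries 2-methylpiperazin-1-yl in place of benzylamino on an aromatic carbon.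

Among the compounds with values here, the only measured single-place step is a 3.0-fold higher number from compound 2 to compound 3 (0.48 log units; beyond the scatter). It is modest and falls within the group that leaves here. Within the data shown here, compound 1 differs from compound 3 in more than one place, so it gives no clean step, although its number is far lower. Among the measured compounds shown here, no measured compound carries the entering group on this position, so a modest step towards a lower number is expected in this assay, with wide uncertainty. The estimated change is a 2.5-fold lower number from compound 3 to compound 4 (0.40 log units; beyond the scatter). Compound 4 is expected at 1200 nM (estimated range 250 nM to 5000 nM).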

Compound 4, concentration for 50% growth inhibition: 9670 nM
Beside the measured number, compound 4's estimate is 8.1-fold (0.91 log units) below it, outside the stated range (above it).
By their numbers in this assay, from the lowest: compound 1; then compound 2; then compound 3; then compound 4.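

In this assay, 2-methylpiperazin-1-yl on this aromatic carbon gives a 3.2-fold higher number from compound 3 to compound 4 (0.51 log units; beyond the scatter), so this ring amine ranks behind benzylamino, not ahead of it. Against (4-methoxybenzyl)amino the same position shows a 9.7-fold higher number from compound 2 to compound 4 (0.99 log units; beyond the scatter), the larger of the two steps, and both lie beyond the scatter. No evidence at hand accounts for the direction of this change.

Open: whether morpholine or unsubstituted piperazine on this carbon would follow 2-methylpiperazin-1-yl or the benzylamino groups. The opposite configuration at the defined stereocentre also remains an open question.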